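Series notes: estimate for compound 4 from compound 2

The source may hold more compounds than are shown below. What is called first, only, known or untested is meant among the compounds shown, and "the series" means these compounds.

Measured so far in a functional assay, read by spectrophotometry, with a stated time of 5 min; on this read-out lower numbers stand for stronger inhibition and higher numbers for weaker inhibition:
compound 1 `O=c1[nH]c2ccccc2cc1/C=N/c1ccccc1O`, 237000 nM
compound 2 `Cc1ccc2[nH]c(=O)c(/C=N/c3ccccc3O)cc2c1`, 286000 nM
compound 3 `CCCC/N=C/c1cc2ccccc2[nH]c1=O`, 246000 nM

Compound 2 has the highest of the three numbers, but its nearest neighbour, compound 3, and the furthest, compound 1, both sit within the scatter of it, so the three cannot be ordered. Within the data shown here, the one step between compounds differing in a single place, a 1.2-fold higher number from compound 1 to compound 2 (0.08 log units; within the scatter), is likewise within the scatter.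

Compound 4 `Cc1ccc2[nH]c(=O)c(/C=N/c3ccc(O)cc3)cc2c1` differs from compound 2 by 4-hydroxyphenyl in place of 2-hydroxyphenyl on a double-bonded nitrogen. Among the measured compounds shown here, no measured step alters the hydroxyphenyl: the methyl step does not bear on this change, and compounds 2 and 3 show only that exchanging the whole group on the double-bonded nitrogen leaves the number within the scatter. No step beyond the scatter is therefore expected in this assay, and compound 4 is estimated at 290000 nM (range 120000 nM to 700000 nM), an expected step of a 1.0-fold higher number from compound 2 to compound 4 (0.01 log units; within the scatter).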

Compound 4, half-maximal inhibitory concentration: 235000 nM
Compound 4: the middle estimate sits 1.2-fold (0.09 log units) above what was measured; measured number inside the range.
By their numbers in this assay, from the lowest: compounds 4, 1, 3 and 2 (each within the scatter of the next).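

In this assay, among these compounds, 4-hydroxyphenyl in place of 2-hydroxyphenyl on a double-bonded nitrogen gives a 1.2-fold lower number from compound 2 to compound 4 (0.09 log units; within the scatter), the only measured step that alters the hydroxyphenyl itself. At this place, the two hydroxyphenyl groups, with the same atoms joined differently, therefore cannot be told apart in this assay. No other data bear on this result.

On these data alone, whether unsubstituted phenyl, or a phenyl carrying a carboxylic acid or an amine, on the double-bonded nitrogen would give a step beyond the scatter remains open. Every step read so far in the series lies within the scatter.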